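A carboxy group on two related cores, dosed in rats

The compounds below may be only part of what the source reports. "The series", "measured", "known", "first", "only" and "open" are said of these compounds alone.

compound 1, `CC1CCC(=NNc2ccccc2)c2ncc(C(=O)NO)c(=O)n21`: > 100 umol/kg
compound 2, `CC1CCC(=NNc2ccccc2C(=O)O)c2ncc(C(=O)NO)c(=O)n21`: > 100 umol/kg
compound 3, `CC1CCC(C)(N=Nc2ccccc2)c2ncc(C(=O)O)c(=O)n21`: 35 umol/kg

Of the compounds shown here, three have been measured in a functional assay on the whole organism with Rattus norvegicus as the target; a lower number here means that less compound is needed, a higher number that more compound is needed for the effect. For compound 1 the result, > 100 umol/kg, is a limit of the assay and not a number. For compound 2 the result, > 100 umol/kg, is likewise a limit. For the measured compounds named here, compound 3 gives 35 umol/kg, the only number among the three.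

The change from compound 1 to compound 2 is carboxy in place of hydrogen on an aromatic carbon. Its step in this assay, a step that the two limits leave unreadable from compound 1 to compound 2, cannot be read, owing to the limit of > 100 umol/kg in this assay, at which 2 of the 3 values shown sit. The difference between the core of compound 1 and the core of compound 3 is not broken down here.

Compound 4, `CC1CCC(C)(N=Nc2ccccc2C(=O)O)c2ncc(C(=O)O)c(=O)n21`, has not been measured yet. It carries the same change as the first pair, (carboxy in place of hydrogen on an aromatic carbon), placed on the core of compound 3. The measured step that the two limits leave unreadable from compound 1 to compound 2 gives no size for this change, so the expectation for compound 4 rests on compound 3 alone, with wide room on either side. In this assay compound 4 is expected to give about 50 umol/kg, somewhere between 15 umol/kg and 150 umol/kg. The expected step is a 1.4-fold higher number from compound 3 to compound 4 (0.15 log units; within the scatter), which is meant as a small one, and a result that is again only a limit is a real possibility.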

Compound 4, dose for 50% inhibition: > 100 umol/kg
Compound 4 ended at the assay's limit; the forecaster's own chance of this, stated with the estimate: 35%; middle value at least 2.0-fold (0.30 log units) away from the limit.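

Placed on the core that gave the only number among the first three compounds, the change from phenyl to 2-carboxyphenyl gives an at least 2.8-fold higher number from compound 3 to compound 4 (0.45 log units; beyond the scatter) in this assay, so more compound is needed once the carboxy group is present, and the true step may be larger than this. Compound 4 gives > 100 umol/kg, which is a limit of the assay and not a number. The same change on the core of compound 1 cannot be read, because both compounds of that pair end at a limit, so this is a single readable case on one core and not a rule shown to carry from one core to another: the limit of > 100 umol/kg in this assay, at which 3 of the 4 values shown sit.

The compounds shown contain no amine, methyl ester or nitrile in place of the carboxy group on that aromatic carbon, so it remains open whether the higher number belongs to the carboxy group itself or would follow from other groups there too. Also open, on these data alone, is how far past its limit compound 4 lies, and what real numbers compound 1 and compound 2 would give.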